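Compound 3 against two limits in the series

A few compounds are considered here, and "the series" means these few. Any claim that something is new, unique, unknown or untested is made for them only; others in the source may bear on it.

- compound 1 `CCCSc1nc(N/N=C/c2ccc(Cl)cc2)c2nnn(Cc3ccccc3)c2n1` gives > 64000 nM as a limit
- compound 2 `CCCSc1nc(N/N=C/c2ccccc2F)c2nnn(Cc3ccccc3)c2n1` gives > 64000 nM as a limit
- compound 3 `CCCSc1nc(N/N=C(\C)c2ccc(Br)cc2)c2nnn(Cc3ccccc3)c2n1` is not yet measured

In a functional assay on MGC-803 cells (Homo sapiens) for antiproliferative activity, read by MTT assay, with a stated time of 72 h (on this read-out lower numbers stand for stronger inhibition and higher numbers for weaker inhibition), compound 2 stands only at a limit (> 64000 nM) and has no number. Within the data shown here, the same limit holds across the series so far (the limit of > 64000 nM in this assay, at which 2 of the 2 values shown sit). Compound 3 differs from compound 2 by one change (a group of 10 heavy atoms (8 carbon, 1 nitrogen, 1 bromine; one six-membered aromatic ring of carbon only) in place of a group of 9 heavy atoms (7 carbon, 1 nitrogen, 1 fluorine; one six-membered aromatic ring of carbon only), on a nitrogen on an aromatic ring). Among the measured compounds shown here, the only measured step is a step that the two limits leave unreadable from compound 1 to compound 2 and gives no size or direction to carry over. No step beyond the scatter is therefore expected in this assay and a further limit is likely. The expected step is an at least 1.6-fold lower number from compound 2 to compound 3 (0.20 log units; that floor lies within the scatter) as an estimate. For compound 3 the estimated value is 40000 nM ( expected range 8000 nM to 64000 nM).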

Compound 3, half-maximal inhibitory concentration: 6020 nM
The estimate for compound 3 lay 6.6-fold (0.82 log units) above the measured number; measured number below the stated range.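

In this assay the group on a nitrogen on an aromatic ring can clearly move the read-out: the group of 10 heavy atoms with bromine gives an at least 10-fold lower number from compound 2 to compound 3 (1.02 log units; beyond the scatter) and also an at least 10-fold lower number from compound 1 to compound 3 (1.02 log units; beyond the scatter). Among these compounds, compound 3 is the first compound here with a number rather than a limit, and the step between compound 1 and compound 2 cannot be read: the limit of > 64000 nM in this assay, at which 2 of the 3 values shown sit.

From the compounds shown here alone, the change brings bromine and one more carbon together, so the share of each remains open. Going by these compounds, whether an amine or a longer chain on this group would lower the number further also remains open.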